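Chloro for fluoro on the urea aryl of compound 3

The compounds below may be only part of what the source reports. "The series", "measured", "known", "first", "only" and "open" are said of these compounds alone.

Measured compounds:
compound 1 `CN(C)CCCNc1nc(-c2ccc(NC(=O)Nc3ccc(F)cc3)cc2)nc2c(Cl)c(Cl)sc12`, 650 nM
compound 2 `CN(C)CCCNc1nc(-c2ccc(NC(=O)Nc3ccc(Cl)cc3Cl)cc2)nc2ccsc12`, 1020 nM
compound 3 `CN(C)CCNc1nc(-c2ccc(NC(=O)Nc3ccc(F)cc3)cc2)nc2ccsc12`, 390 nM

Of the compounds shown here, three sharing one core have been tested in a functional assay on NCI-H460 cells (Homo sapiens) for cytotoxicity, read by MTT assay, with a stated time of 72 h; a higher number here means a weaker inhibitor, a lower number a stronger inhibitor. Compound 1 gives 650 nM, compound 2 gives 1020 nM and compound 3 gives 390 nM. Compound 3 has the lowest of the three numbers. Its gap to compound 1 lies within the usual scatter of this assay, so no order between these two can be claimed; its gap to compound 2 lies beyond the scatter.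

Compound 4 `CN(C)CCNc1nc(-c2ccc(NC(=O)Nc3ccc(Cl)cc3)cc2)nc2ccsc12` has not yet been measured. It differs from compound 3 in one place: chloro in place of fluoro on an aromatic carbon. The halogen is exchanged on the phenyl ring attached to the urea, and nothing else in the molecule changes.

Among the measured compounds shown here, no step between measured compounds isolates this exchange, so there is no direct precedent within this set. On the numbers shown, the change from compound 3 to compound 4 is expected to be small, with no direction beyond the scatter of this assay, as a 1.1-fold higher number from compound 3 to compound 4 (0.03 log units; within the scatter). Compound 4 is therefore estimated to give about 420 nM in this assay, with a plausible range from 200 nM to 900 nM.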

Compound 4, half-maximal inhibitory concentration: 130 nM
The estimate for compound 4 lay 3.2-fold (0.51 log units) above the measured number, outside the stated range (below it).
By their numbers in this assay, from the lowest: compound 4; then compounds 3, 1 and 2 (each within the scatter of the next, the first and the last beyond it).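

Replacing 4-fluorophenyl with 4-chlorophenyl swaps a single halogen atom and leaves the ring, the hydrogen-bond donor and acceptor counts and the net charge unchanged, yet it gives a 3.0-fold lower number from compound 3 to compound 4 (0.48 log units; beyond the scatter) in this assay. Among the compounds shown here, this is the first step in the set that isolates a single change, and it shows that the read-out at this aromatic carbon, para to a large group, depends on which halogen is present, although the step itself is modest. No measurement shown bears on the reason for this step.

For the compounds shown here, only this one pair speaks to the position, so it remains open whether a bromo, a methyl or a trifluoromethyl group there would extend the step, and whether a plain hydrogen, a methoxy group or a nitrile would reverse it. As far as these compounds go, it is equally open whether the same exchange of fluoro for chloro would give a step of similar size on the longer chain carried by compound 1 and compound 2, or on the chlorinated core of compound 1.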